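The source may report more compounds than this note shows. Statements on the series, on what has been measured and on what is new or still open speak of the compounds shown alone.

Working notes on the series, all read in a functional assay on HeLa cells (Homo sapiens) for antiproliferative activity, read by MTT assay, with a stated time of 48 h (a lower number here means a stronger inhibitor, a higher number a weaker inhibitor), on the shared core. Compound 1 `C=C(c1ccc(OC)cc1NC(=O)CO)c1ccc(OC)c2c1C=CC(C)(C)O2` gives 100 nM in this read-out, compound 2 `C=C(c1ccc(OC)cc1NC(=O)CNC)c1ccc(OC)c2c1C=CC(C)(C)O2` gives 500 nM and compound 3 `C=C(c1ccc(OC)cc1NC(=O)CNCC)c1ccc(OC)c2c1C=CC(C)(C)O2` gives 2590 nM as the highest number of the three, with its steps to both others beyond the scatter.

The next entry is compound 4 `C=C(c1ccc(OC)cc1NC(=O)CN(C)C)c1ccc(OC)c2c1C=CC(C)(C)O2`, with dimethylamino in place of ethylamino on a saturated chain carbon bound to a carbonyl carbon as the counted difference. The two have the same atoms, joined differently.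

Among the measured compounds shown here, no measured step covers this exact change. The large step of a 26-fold higher number from compound 1 to compound 3 (1.41 log units; beyond the scatter) and the modest step of a 5.0-fold higher number from compound 1 to compound 2 (0.70 log units; beyond the scatter) both concern hydroxy and show only that each amine gives a higher number than hydroxy. Closest is the modest step of a 5.2-fold higher number from compound 2 to compound 3 (0.71 log units; beyond the scatter) for methyl in place of hydrogen on a saturated chain carbon bound to an amine nitrogen. Compound 4 no longer carries the ethylamino group behind that step, so part of it is expected to be recovered, though not with certainty.

A modest move toward a lower number is therefore expected, and the estimated change is a 2.9-fold lower number from compound 3 to compound 4 (0.46 log units; beyond the scatter) in this assay for now. Compound 4 is estimated at 900 nM with an expected range from 250 nM to 3000 nM in this read-out.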

Compound 4, half-maximal inhibitory concentration: 790 nM
Compound 4: the middle estimate sits 1.1-fold (0.06 log units) above what was measured, within the range that was stated.
By their numbers in this assay, from the lowest: compound 1; then compounds 2 and 4 (each within the scatter of the next); then compound 3.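

On a saturated chain carbon bound to a carbonyl carbon, dimethylamino in place of ethylamino gives a 3.3-fold lower number from compound 3 to compound 4 (0.52 log units; beyond the scatter) in this assay with the same heavy atoms, so the way the two carbons are attached to the nitrogen changes the read-out even with the atom count held equal. Methyl in place of hydrogen on the amine nitrogen gives a 1.6-fold higher number from compound 2 to compound 4 (0.20 log units; within the scatter) in this assay and leaves the two compounds inseparable, while methyl on the saturated chain carbon bound to the amine nitrogen gave a 5.2-fold higher number from compound 2 to compound 3 (0.71 log units; beyond the scatter) as the step beyond the scatter, so among these amines only the ethylamino group stands apart. Hydroxy still holds the lowest number, with a 7.9-fold higher number from compound 1 to compound 4 (0.90 log units; beyond the scatter) as the step to the new amine, and compound 4 joins compounds 2 and 3 in lying above compound 1 with no exception among the four.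

No measurement at hand accounts for any of these steps.

Still open, from the compounds shown here alone, is whether the separation of ethylamino extends to a longer chain on the nitrogen such as propylamino or diethylamino, and how a ring amine such as pyrrolidine or morpholine, or a methoxy group in place of hydroxy, would read at this position.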